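A smaller thiazole group on the sulfur

This account rests on a few compounds, and the source may have more. Where it says the series, first, only, none or still open, it means among the compounds named here.

In a functional assay on KYSE-70 cells for antiproliferative activity against KYSE-70 cell line (Homo sapiens), read by MTT assay, with a stated time of 72 h (on this read-out higher numbers stand for weaker inhibition and lower numbers for stronger inhibition), compound 3 (`C#CCSc1nc(Sc2nc3ccccc3s2)c(C#N)c(-c2cc(OC)c(OC)c(OC)c2)n1`) gives > 20000 nM as a limit of the assay, not a number. Compound 3 therefore stands at the assay's ceiling (the limit of > 20000 nM in this assay, at which 2 of the 3 values shown sit). Compound 1 (`C#CCSc1nc(Sc2nc(C)c(C)s2)c(C#N)c(-c2cc(OC)c(OC)c(OC)c2)n1`) likewise gives > 20000 nM as a limit. Compound 2 (`C#CCSc1nc(Sc2nncs2)c(C#N)c(-c2cc(OC)c(OC)c(OC)c2)n1`) alone reaches a true number, 8250 nM with its 1,3,4-thiadiazol-2-yl group.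

Compound 4 (`C#CCSc1nc(Sc2nc(C)cs2)c(C#N)c(-c2cc(OC)c(OC)c(OC)c2)n1`) brings one change (4-methyl-1,3-thiazol-2-yl in place of 1,3-benzothiazol-2-yl on a sulfur): 4-methyl-1,3-thiazol-2-yl replaces 1,3-benzothiazol-2-yl on a sulfur. For the measured compounds named here, three measured steps bear on it. Swapping in the thiadiazolyl group gave an at least 2.4-fold lower number from compound 1 to compound 2 (0.38 log units; beyond the scatter) and moving on to the benzothiazolyl group gave an at least 2.4-fold higher number from compound 2 to compound 3 (0.38 log units; beyond the scatter) as its counterpart. Between the two limits lies a step that the two limits leave unreadable from compound 1 to compound 3 and no size can be read there.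

The entering group most resembles the 4,5-dimethyl-1,3-thiazol-2-yl group of compound 1, whose limit of > 20000 nM suggests little gain. The expected change is an at least 1.1-fold lower number from compound 3 to compound 4 (0.07 log units; that floor lies within the scatter) and probably nothing beyond the scatter. For compound 4 the estimate is 17000 nM with an expected range of 7000 nM to 30000 nM. Compound 4 may again end at a limit of the assay.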

Compound 4, half-maximal inhibitory concentration: > 20000 nM
Compound 4: a limit, no number; the forecaster's own chance of this, stated with the estimate: 55%; at least 1.1-fold (0.07 log units) between middle value and limit.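

In this assay compound 4 gives > 20000 nM, a limit of the assay and not a number, and it joins the others at the ceiling: the limit of > 20000 nM in this assay, at which 3 of the 4 values shown sit. Placing the 4-methyl-1,3-thiazol-2-yl group on this sulfur instead of the 1,3,4-thiadiazol-2-yl group gives an at least 2.4-fold higher number from compound 2 to compound 4 (0.38 log units; beyond the scatter), so among the groups shown only the 1,3,4-thiadiazol-2-yl group of compound 2 yields a true number. The steps among compounds 1, 3 and 4 cannot be read, but the new result shows that neither losing the six-membered ring of the benzothiazolyl group nor losing one methyl from the dimethylthiazolyl group is enough to bring a number.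

Still open, going by these compounds, is whether a plain 1,3-thiazol-2-yl group, with no methyl at all, would reach a number. On these data alone, the effect of a 5-methyl-1,3,4-thiadiazol-2-yl group on this sulfur also remains unknown.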